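One Added Methyl and a Growth-Inhibition Estimate

The source may report more compounds than this note shows. Statements on the series, on what has been measured and on what is new or still open speak of the compounds shown alone.

Compound 1 (`Cc1ccc(Nc2ncc3c(n2)N(C)C(=O)N(c2cc(NC(=O)c4ccc(C)c(C(F)(F)F)c4)ccc2C)C3)cn1`) is the starting point. In an ADME assay on BaF3 cells (Mus musculus) for inhibition, read by CellTiter-Glo, with a stated time of 72 h (a higher number here means a weaker inhibitor of growth, a lower number a stronger inhibitor of growth), compound 1 gives 870 nM and compound 2 (`Cc1ccc(Nc2ncc3c(n2)N(C)C(=O)N(c2cc(NC(=O)c4ccc(CN5CCC(N(C)C)C5)c(C(F)(F)F)c4)ccc2C)C3)cn1`) gives 636 nM in the same test. These two values lie within the normal scatter of repeated measurements, so compound 1 has no clear rank.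

Compound 3 (`CCN1C(=O)N(c2cc(NC(=O)c3ccc(C)c(C(F)(F)F)c3)ccc2C)Cc2cnc(Nc3ccc(C)nc3)nc21`) differs from compound 1 in one place (methyl in place of hydrogen on a saturated chain carbon bound to an amide-type nitrogen in a ring): methyl in place of hydrogen on a saturated chain carbon bound to an amide-type nitrogen in a ring. Read one bond further out, a methyl becomes an ethyl.

Going by the values given here, only one measured step is available. That step, a 1.4-fold lower number from compound 1 to compound 2 (0.14 log units; within the scatter), lies at a different place on the molecule, so it bears on this change only indirectly. Among the compounds with values here, no measured compound tests the new place directly. For this assay no step beyond the scatter is therefore expected, in either direction, though this is a cautious expectation. The estimated step is a 1.1-fold lower number from compound 1 to compound 3 (0.04 log units; within the scatter) and remains only an estimate. Compound 3 is estimated at 800 nM with a range from 350 nM to 1800 nM expected.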

Compound 3, concentration for 50% growth inhibition: 708 nM
The estimate for compound 3 lay 1.1-fold (0.05 log units) above the measured number, and the stated range covers the measured number.
By their numbers in this assay, from the lowest: compounds 2, 3 and 1 (each within the scatter of the next).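

In this assay, going by these compounds alone, the change of methyl in place of hydrogen on a saturated chain carbon bound to an amide-type nitrogen in a ring gives a 1.2-fold lower number from compound 1 to compound 3 (0.09 log units; within the scatter), and this is the first measured step at this place on the molecule. Within the data shown here, compound 2 differs from compound 1 only at another place, so it could say nothing directly about this one, whereas compound 3 now shows that a methyl can become an ethyl here with no step that stands out from the scatter. Nothing measured here gives a reason for this result or ties it to any property of the added carbon.

Going by these compounds, a single step of one carbon says little about larger groups, so it remains open whether a longer chain such as propyl, a cyclopropyl ring, or a chain ending in an amine would also stay within the scatter at this place. On these data alone, it also remains open whether the ethyl would behave the same way in a compound carrying the 3-(dimethylamino)pyrrolidin-1-yl group of compound 2.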